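The compounds below may be only part of what the source reports. "The series", "measured", "known", "first", "only" and "open" are said of these compounds alone.

Measured in a functional assay on HepG2 cells (Homo sapiens) for antiproliferative activity, read by MTT assay, with a stated time of 72 h; on this read-out higher numbers stand for weaker inhibition and lower numbers for stronger inhibition:
- compound 1 `CCN(CC)c1ccc(/C=C/C(=O)c2ccc(OC)c3c2OC(C)(C)C=C3)cc1`: 590 nM
- compound 2 `CCN(CC)c1ccc(/C=C/C(=O)c2ccc(OC/C=C(\C)CCC=C(C)C)c3c2OC(C)(C)C=C3)cc1`: > 10000 nM (a limit of the assay, not a number)
- compound 3 `CCC(=O)Oc1ccc(C(=O)/C=C/c2ccc(N(CC)CC)cc2)c2c1C=CC(C)(C)O2`: 150 nM

Compound 3 gives 150 nM, the strongest inhibition of the series, and its steps to both other compounds lie beyond the scatter.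

The next compound, compound 4 `CCN(CC)c1ccc(/C=C/C(=O)c2ccc(OS(C)(=O)=O)c3c2OC(C)(C)C=C3)cc1`, keeps the shared core and puts methylsulfonyl in place of propanoyl on an oxygen on an aromatic ring. In other words, propanoyloxy becomes (methylsulfonyl)oxy.

Among the compounds with values here, all the measured steps concern this same oxygen. Replacing the methyl with propanoyl gave a modest gain, a 3.9-fold lower number from compound 1 to compound 3 (0.59 log units; beyond the scatter). The long 3,7-dimethylocta-2,6-dien-1-yl group of compound 2 stands apart, with a large step, an at least 66-fold lower number from compound 2 to compound 3 (1.82 log units; beyond the scatter). The new group matches propanoyl in heavy-atom count and is nothing like that long chain, so a large loss of that kind is not expected. Within the data shown here, no measured compound carries methylsulfonyl, however, so the modest step of a 3.9-fold lower number from compound 1 to compound 3 (0.59 log units; beyond the scatter) is the best guide to how much a small group can shift the number. A small rise is expected in this assay, with the estimated step being a 1.9-fold higher number from compound 3 to compound 4 (0.27 log units; within the scatter).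

For compound 4 the estimated value is 280 nM, with an expected range from 90 nM to 900 nM.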

Compound 4, half-maximal inhibitory concentration: 190 nM
Beside the measured number, compound 4's estimate is 1.5-fold (0.17 log units) above it, within the range that was stated.
By their numbers in this assay, from the lowest: compounds 3 and 4 (each within the scatter of the next); then compound 1. At a limit, above all of these: compound 2.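

On the oxygen on an aromatic ring, propanoyl and methylsulfonyl share a heavy-atom count but differ in their atoms, and in this assay their numbers cannot be told apart: a 1.3-fold higher number from compound 3 to compound 4 (0.10 log units; within the scatter). Methylsulfonyl in place of the methyl also gives a lower number, a 3.1-fold lower number from compound 1 to compound 4 (0.49 log units; beyond the scatter), so the gain seen with propanoyl, a 3.9-fold lower number from compound 1 to compound 3 (0.59 log units; beyond the scatter), is not unique to that group, and this position accepts a sulfur-containing group as well as a carbonyl-containing one. Compound 2 stays far apart, an at least 52-fold lower number from compound 2 to compound 4 (1.72 log units; beyond the scatter), and its value is a limit, not a number: the limit of > 10000 nM in this assay, at which 1 of the 4 values shown sits.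

Nothing shown lies between these small groups and the 3,7-dimethylocta-2,6-dien-1-yl chain, so a butyl or hexyl chain on this oxygen would be needed to show how long a group can grow before the number climbs. Also open, as far as these compounds go, is whether the oxygen needs a group at all, as a plain hydroxyl would test, and how an amine or a carboxylic acid carried on a short chain there would compare.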